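Swapping Benzoyl for Cyano on a Sulfonyl-Bearing Double Bond

A few compounds are considered here, and "the series" means these few. Any claim that something is new, unique, unknown or untested is made for them only; others in the source may bear on it.

Compounds measured so far:
Compound 1, `COc1ccc(-c2[nH]c3ccccc3c2/C=C(\C#N)S(=O)(=O)c2ccccc2)cc1` — 1100 nM in a functional assay on A498 cells (Homo sapiens) for inhibition, read by sulforhodamine B assay, with a stated time of 48 h; a lower number here means a stronger inhibitor of growth, a higher number a weaker inhibitor of growth
Compound 2, `O=C(/C(=C\c1c(-c2ccccc2)[nH]c2ccccc12)S(=O)(=O)c1ccccc1)c1ccccc1` — "not determined" (no result reported) in this assay

Compound 2 stands nowhere on the numbers: for it this assay reported no value, so there is no figure to place it above or below compound 1.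

Compound 3, `N#C/C(=C\c1c(-c2ccccc2)[nH]c2ccccc12)S(=O)(=O)c1ccccc1`, is the next compound. It differs from compound 2 by cyano in place of benzoyl on a double-bonded chain carbon bound to a double-bonded chain carbon and a sulfonyl sulfur. Since compound 2 has no number, the size and direction of this step cannot be read from any measured pair, and nothing beyond the usual scatter can be claimed for it.

What does exist is compound 1, which carries the same cyano-bearing double bond and differs from compound 3 only in the group on its pendant ring; in this assay compound 1 gives 1100 nM. Compound 3 is expected to land near that figure, estimated at 1500 nM, with a range from 400 nM to 6000 nM.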

Compound 3, concentration for 50% growth inhibition: 11000 nM
For compound 3 the middle estimate is 7.3-fold (0.87 log units) below the measured one; measured number above the stated range.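

The new value shifts attention from the double bond to the pendant ring. In this assay, putting hydrogen in place of methoxy on an aromatic carbon gives a 10-fold higher number from compound 1 to compound 3 (1.00 log units; beyond the scatter), a step beyond the usual scatter, so the methoxy-bearing compound is the stronger inhibitor of growth and this aromatic carbon is not a silent spot on the molecule. Nothing available explains this loss of strength.

The swap of benzoyl for cyano remains unreadable: compound 2 has no number to set against compound 3. Also open, on these data alone, is how an amine or an ethoxy group on that same aromatic carbon would compare with methoxy, and whether a benzoyl compound carrying methoxy would follow the same trend.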